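The source may hold more compounds than are shown below. What is called first, only, known or untested is meant among the compounds shown, and "the series" means these compounds.

Of the compounds shown here, three built on one shared core have been measured in a functional assay on A-375 cells (Homo sapiens) for antiproliferative activity, read by CCK-8 assay, with a stated time of 72 h, tested at 2 uM; a higher number here means a stronger effect of the compound at the concentration tested, a lower number a weaker effect. Compound 1, `Nc1ccccc1NC(=O)c1ccc(CSC(=S)N2CCN(C3CCCCC3)CC2)cc1`, gives 31.7%. Compound 2, `CN(Cc1cccnc1)C(=S)SCc1ccc(C(=O)Nc2ccccc2N)cc1`, gives 39.4%, and compound 3, `Nc1ccccc1NC(=O)c1ccc(CSC(=S)N2CCc3cc(Cl)ccc32)cc1`, gives 31.9%. Compound 1 thus carries the smallest of the three numbers, but its gap to compound 3 and its gap to compound 2 both lie within the usual scatter of such measurements, so the three compounds cannot really be told apart. Within the data shown here, the only step among the measured compounds, a number 7.5 percentage points lower from compound 2 to compound 3 (within the scatter), also stays within that scatter.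

Compound 4, `Nc1ccccc1NC(=O)c1ccc(CSC(=S)N2CCN(c3ccccc3)CC2)cc1`, has not yet been measured. It differs from compound 1 in one place: phenyl in place of cyclohexyl on an amine nitrogen in a ring. Among the measured compounds shown here, the step from compound 2 to compound 3 alters the group on the thiocarbonyl carbon rather than the group on the ring nitrogen, so it bears only loosely on this change; still, it is the one comparison available, and it shows a swap of one sizeable group for another leaving the read-out within the scatter. A step of similar size, with no clear direction, is therefore expected here, namely a number 1.3 percentage points higher from compound 1 to compound 4 (within the scatter). Compound 4 is expected to give about 33% in this assay, within a likely range from 18% to 48%.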

Compound 4, a percentage reported as inhibition, at one concentration (the size of the read-out at that concentration, not a potency): 27.5%
Compound 4: the middle estimate sits 5.5 percentage points above what was measured, within the range that was stated.
By their numbers in this assay, from the lowest: compounds 4, 1, 3 and 2 (each within the scatter of the next, the first and the last beyond it).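

In this assay, phenyl in place of cyclohexyl on an amine nitrogen in a ring gives a number 4.2 percentage points lower from compound 1 to compound 4 (within the scatter), so the two groups cannot be told apart at this position. Both are six-membered rings of carbon only with the same number of heavy atoms and no hydrogen-bond donors or acceptors, and the main difference listed between them is that one ring is aromatic and the other is not. Among these compounds, this is the first measured step at this nitrogen, and it shows that making the ring aromatic, with the rest of compound 1 unchanged, leaves the read-out within the usual scatter. No measurement available here bears on what lies behind this result.

Both groups are large carbon rings, so the compounds shown leave open whether something quite different on this nitrogen, such as a methyl group, a longer chain ending in an amine, or a chain carrying a carboxylic acid, would move the read-out beyond the scatter. From the compounds shown here alone, it also remains open whether a chlorine or methoxy group on the phenyl ring of compound 4 would make any measurable difference.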